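From piperidin-1-yl to 3-(trifluoromethyl)pyrrolidin-1-yl: a solubility note

The source may hold more compounds than are shown below. What is called first, only, known or untested is meant among the compounds shown, and "the series" means these compounds.

Of the compounds shown here, three have numbers so far in a physicochemical assay for solubility, read by HPLC, in phosphate buffer, at pH 6.5 (a higher number here means a more soluble compound, a lower number a less soluble compound), on a shared scale. Compound 1 (`COC(=O)C1=C(C)NC(c2nccs2)=N[C@]1(C)c1ccc(F)cc1`) reads 178 ug/mL in this measure, compound 2 (`COC(=O)C1=C(C)NC(c2nccs2)=NC1(C)c1ccc(Cl)cc1`) reads 14 ug/mL in the same measure and compound 3 (`COC(=O)C1=C(CN2CCCCC2)NC(c2nccs2)=NC1(C)c1ccc(F)cc1`) reads 282 ug/mL on that scale. Compound 3 sits within the scatter of compound 1 and beyond the scatter of compound 2.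

Compound 4 (`COC(=O)C1=C(CN2CCC(C(F)(F)F)C2)NC(c2nccs2)=NC1(C)c1ccc(F)cc1`) carries 3-(trifluoromethyl)pyrrolidin-1-yl in place of piperidin-1-yl on a saturated chain carbon bound to a double-bonded ring carbon and has no number yet. Among the compounds with values here, no measured pair isolates this change, so the expectation is a loose one. In this assay a downward move is expected: the estimated step is a 4.0-fold lower number from compound 3 to compound 4 (0.61 log units; beyond the scatter) and it would lie beyond the scatter. Compound 2 at 14 ug/mL shows how low the series can read, so the range stays wide. For compound 4 the estimate is 70 ug/mL with an expected range from 20 ug/mL to 250 ug/mL in this measure.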

Compound 4, solubility: 13 ug/mL
Beside the measured number, compound 4's estimate is 5.4-fold (0.73 log units) above it, and the stated range ends above it.
By their numbers in this assay, from the lowest: compounds 4 and 2 (each within the scatter of the next); then compounds 1 and 3 (each within the scatter of the next).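

At the saturated chain carbon bound to a double-bonded ring carbon, the choice of ring amine matters greatly in this assay: 3-(trifluoromethyl)pyrrolidin-1-yl in place of piperidin-1-yl gives a 22-fold lower number from compound 3 to compound 4 (1.34 log units; beyond the scatter), a large step beyond the scatter. Within the data shown here, this is the only measured pair that differs in one place, and it combines a five-membered ring in place of a six-membered ring with the addition of trifluoromethyl, so the step belongs to the whole exchange and not to either part. No measurement at hand bears on the reason for the step.

Still open, as far as these compounds go, is how the step divides between ring size and trifluoromethyl, which unsubstituted pyrrolidin-1-yl at this place would help to separate. Also open, from the compounds shown here alone, is how morpholin-4-yl or a carboxylic acid on the same saturated chain carbon would read in this assay.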